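A few compounds are considered here, and "the series" means these few. Any claim that something is new, unique, unknown or untested is made for them only; others in the source may bear on it.

For the measured compounds named here, in a functional assay on MCF7 cells (Homo sapiens) for cytotoxicity, read by MTT assay and propidium iodide staining, with a stated time of 24 h (on this read-out higher numbers stand for weaker inhibition and lower numbers for stronger inhibition), compound 1 `Cc1ccc(-c2nnc(SCC(=O)c3ccc(Br)cc3)o2)c(O)c1` gives 2070 nM and compound 2 `O=C(CSc1nnc(-c2ccccc2F)o1)c1ccc(Br)cc1` gives 240 nM, so compound 2 has the lower of the only two numbers so far. Compound 3 `O=C(CSc1nnc(-c2ccnc(Cl)c2)o1)c1ccc(Br)cc1` differs from compound 2 in one group: 2-chloropyridin-4-yl in place of 2-fluorophenyl on an aromatic carbon. Here 2-chloropyridin-4-yl stands in place of 2-fluorophenyl on an aromatic carbon. Going by the values given here, one measured step bears on this place: an 8.6-fold lower number from compound 1 to compound 2 (0.94 log units; beyond the scatter), when 2-fluorophenyl replaced 2-hydroxy-4-methylphenyl. Among the compounds with values here, that modest step, beyond the scatter, shows that a swap here can move the number, but no measured compound carries the incoming group, so the direction remains uncertain. Going by that step alone, and with compound 2 already at 240 nM, a smaller move toward a higher number is expected: a 2.1-fold higher number from compound 2 to compound 3 (0.32 log units; beyond the scatter). For compound 3 the estimated value is 500 nM, with an expected range from 120 nM to 2000 nM.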

Compound 3, half-maximal inhibitory concentration: 270 nM
The estimate for compound 3 lay 1.9-fold (0.27 log units) above the measured number, within the range that was stated.
By their numbers in this assay, from the lowest: compounds 2 and 3 (each within the scatter of the next); then compound 1.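

In this assay, the swap of 2-fluorophenyl for 2-chloropyridin-4-yl gives a 1.1-fold higher number from compound 2 to compound 3 (0.05 log units; within the scatter) and so leaves the two compounds indistinguishable, even though the ring now holds a nitrogen and a chlorine and the fluorine is gone. The other comparison, a 7.7-fold lower number from compound 1 to compound 3 (0.88 log units; beyond the scatter) when 2-chloropyridin-4-yl replaces 2-hydroxy-4-methylphenyl, shows that two different rings at this place both separate clearly from compound 1, so among these compounds the lower number needs neither fluorine nor an all-carbon ring. No measurement available here explains why these two rings match or why compound 1 stands apart. Still open, on these data alone, is whether the hydroxyl or the methyl of compound 1 accounts for its gap. Also open, as far as these compounds go, is how an amine, a carboxylic acid or a longer chain would fare at this place.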